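Hydroxy to methoxy on the aryl ring of compound 3

The source may report more compounds than this note shows. Statements on the series, on what has been measured and on what is new or still open speak of the compounds shown alone.

Three compounds of this series have been run in a functional assay on SK-MEL-28 cells (Homo sapiens) for inhibition, read by sulforhodamine B assay, with a stated time of 48 h, tested at 10 uM; a lower number here means a stronger effect, a higher number a weaker effect of the compound at the concentration tested. Compound 1 `COc1cc(Cl)cc(-c2nn(-c3cccc(NC(=O)Nc4cccc(C(F)(F)F)c4)c3)cc2-c2ccncc2)c1` gives 14.1%, compound 2 `COc1cc(Cl)cc(-c2nn(-c3cccc(NC(=O)c4cccc(C(F)(F)F)c4)c3)cc2-c2ccncc2)c1` gives 70.4%, and compound 3 `O=C(Nc1cccc(-n2cc(-c3ccncc3)c(-c3cc(O)cc(Cl)c3)n2)c1)c1cc(C(F)(F)F)cc(C(F)(F)F)c1` gives 63.6%. Compound 3 stands second highest of the three numbers: its nearest neighbour is compound 2, within the scatter, and its furthest is compound 1, which lies well beyond the scatter.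

Among the measured compounds shown here, the one measured step, a number 56.3 percentage points higher from compound 1 to compound 2 (beyond the scatter), concerns the carbonyl group and not the oxygen on the aryl ring, so it does not bear on the change now in question.

Compound 4 `COc1cc(Cl)cc(-c2nn(-c3cccc(NC(=O)c4cc(C(F)(F)F)cc(C(F)(F)F)c4)c3)cc2-c2ccncc2)c1` differs from compound 3 by methyl in place of hydrogen on an oxygen on an aromatic ring. For the measured compounds named here, no measured pair shows this change on its own, and the amide carried by compound 3 and compound 4 is found in no other measured compound. With nothing to lean on, no step beyond the scatter is expected: the estimate is a number 0.4 percentage points higher from compound 3 to compound 4 (within the scatter). For compound 4 in this assay the expected value is 64%, with a range from 44% to 84%.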

Compound 4, a percentage reported as activity, at one concentration (the size of the read-out at that concentration, not a potency): 78.8%
Beside the measured number, compound 4's estimate is 14.8 percentage points below it; low and high end bracket the measured number.
By their numbers in this assay, from the lowest: compound 1; then compounds 3, 2 and 4 (each within the scatter of the next, the first and the last beyond it).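

Methyl in place of hydrogen on this oxygen gives a number 15.2 percentage points higher from compound 3 to compound 4 (beyond the scatter) in this assay and so, with the bis(trifluoromethyl)phenyl amide held fixed, the hydroxy form goes with the stronger effect at the concentration tested. The second trifluoromethyl on the amide's aromatic ring gives a number 8.4 percentage points higher from compound 2 to compound 4 (within the scatter) and so has no readable effect among the methoxy compounds. Nothing at hand accounts for the step at this oxygen.

Whether the same step appears with the urea of compound 1 or the single trifluoromethyl amide of compound 2 remains open, as the hydroxy partners of those compounds are not among those shown here. Also open, going by these compounds, is how an ethoxy group, a longer alkoxy chain or an amine would compare with hydroxy and methoxy on this aromatic ring.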